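The source may hold more compounds than are shown below. What is called first, only, known or untested is meant among the compounds shown, and "the series" means these compounds.

Compound 1 `CCOC(=O)c1nc(C)c2c(c1N)C(=O)N(Cc1ccccc1)C2=O` carries an ethoxy group on its carbonyl carbon. In a physicochemical assay for solubility, using the shake flask method, in simulated intestinal fluid, measured as kinetic solubility, with a stated time of 2 h, at 25 degrees C, at pH 6.5 (on this read-out lower numbers stand for lower solubility and higher numbers for higher solubility), compound 1 returns only a limit, < 5000 nM. Compound 2 `Cc1nc(C(=O)NC#N)c(N)c2c1C(=O)N(Cc1ccccc1)C2=O` gives 185000 nM in this assay. For the measured compounds named here, the single measured step, an at least 37-fold higher number from compound 1 to compound 2 (1.56 log units; beyond the scatter), is the only comparison the numbers allow. Compound 3 `Cc1noc(-c2nc(C)c3c(c2N)C(=O)N(Cc2ccc(-n4cccn4)cc2)C3=O)n1` likewise returns only a limit in this assay, < 5000 nM. It thus stands at the low end of the numbers shown, sharing its position with compound 1 (the limit of < 5000 nM in this assay, at which 2 of the 3 values shown sit). Compound 4 `Cc1noc(-c2nc(C)c3c(c2N)C(=O)N(Cc2ccc(S(C)(=O)=O)cc2)C3=O)n1` differs from compound 3 in one place: methylsulfonyl in place of 1H-pyrazol-1-yl on an aromatic carbon. Going by the values given here, no measured step touches this position or either of these two groups, and the step of an at least 37-fold higher number from compound 1 to compound 2 (1.56 log units; beyond the scatter) concerns a different part of the shared core, so it does not bear on the present change. A modest rise in this assay is nevertheless expected, an at least 1.6-fold higher number from compound 3 to compound 4 (0.20 log units; that floor lies within the scatter), with a real chance that the measurement again stops at a limit. Compound 4 is accordingly estimated at 8000 nM, with a range from 2000 nM to 40000 nM.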

Compound 4, solubility: < 5000 nM
Compound 4: a limit, no number (the forecaster's own chance of this, stated with the estimate: 45%); middle value at least 1.6-fold (0.20 log units) from the limit.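

In this assay, compound 3 and compound 4 both return only limits, and the step between them cannot be read. The compounds shown leave open whether methylsulfonyl and 1H-pyrazol-1-yl on this aromatic carbon differ at all in this assay, as neither compound gives a number.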